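Shifting the trifluoromethyl along the amide-borne ring

A few compounds are considered here, and "the series" means these few. Any claim that something is new, unique, unknown or untested is made for them only; others in the source may bear on it.

Of the compounds shown here, three that share one core have been measured in a physicochemical assay for lipophilicity, using the shake flask method, in phosphate buffer, measured as octanol-water partition, at pH 7.4; on this read-out lower numbers stand for lower lipophilicity and higher numbers for higher lipophilicity. Compound 1 `COc1cc(-c2cc(C(=O)O)c3ccccc3n2)ccc1OCC(=O)Nc1cccc(C)c1` gives 1.5, compound 2 `COc1cc(-c2cc(C(=O)O)c3ccccc3n2)ccc1OCC(=O)Nc1ccccc1F` gives 0.9 and compound 3 `COc1cc(-c2cc(C(=O)O)c3ccccc3n2)ccc1OCC(=O)Nc1ccccc1C(F)(F)F` gives 1.3. Compound 2 stands lowest of the three: its nearest neighbour is compound 3, reached by a number 0.40 log units higher from compound 2 to compound 3 (beyond the scatter), and its furthest is compound 1, separated by a number 0.60 log units lower from compound 1 to compound 2 (beyond the scatter). Compound 4 `COc1cc(-c2cc(C(=O)O)c3ccccc3n2)ccc1OCC(=O)Nc1ccc(C(F)(F)F)cc1` has not yet been measured. It differs from compound 2 by 4-(trifluoromethyl)phenyl in place of 2-fluorophenyl on an amide-type nitrogen. Within the data shown here, two measured steps bear on this change. The step of a number 0.40 log units higher from compound 2 to compound 3 (beyond the scatter) shows what happens when trifluoromethyl replaces fluoro on the amide-borne ring, while a number 0.20 log units lower from compound 1 to compound 3 (within the scatter) shows that 2-(trifluoromethyl)phenyl and 3-methylphenyl give numbers close together. Among the measured compounds shown here, no measured pair separates 4-(trifluoromethyl)phenyl from 2-(trifluoromethyl)phenyl, so the expectation for compound 4 rests mainly on compound 3 and its 1.3. Taking compound 3 as the closest guide, the expected step is a number 0.50 log units higher from compound 2 to compound 4 (beyond the scatter), a modest rise of about the measured size or slightly more. The estimate for compound 4 is 1.4, with a range from 1 to 1.9.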

Compound 4, distribution coefficient: 1.6
Compound 4: the middle estimate sits 0.20 log units below what was measured; measured number inside the range.
By their numbers in this assay, from the lowest: compound 2; then compounds 3, 1 and 4 (each within the scatter of the next).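

In this assay, among these compounds, the change from 2-fluorophenyl to 4-(trifluoromethyl)phenyl on the amide-type nitrogen gives a number 0.70 log units higher from compound 2 to compound 4 (beyond the scatter), and this is the only one of the new steps to clear the scatter. Among the compounds shown here, the first direct comparison of the two trifluoromethyl-bearing rings gives a number 0.30 log units higher from compound 3 to compound 4 (within the scatter), so the read-out does not resolve 4-(trifluoromethyl)phenyl from 2-(trifluoromethyl)phenyl, and the comparison with 3-methylphenyl gives a number 0.10 log units higher from compound 1 to compound 4 (within the scatter), which likewise leaves those two groups unresolved. Across these four compounds, only compound 2 is separated from all the others by steps beyond the scatter, while compounds 1, 3 and 4 all lie within the scatter of one another.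

Nothing available here explains why the 2-fluorophenyl compound stands apart from the other three. From the compounds shown here alone, it also remains open whether this narrow grouping would hold if a nitrile, an amine or a longer chain took the place of the trifluoromethyl on the amide-borne ring, since the four compounds carry only fluoro, methyl and trifluoromethyl there.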